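Swapping a Naphthyl Group for a Methylphenyl Group

The compounds below may be only part of what the source reports. "The series", "measured", "known", "first", "only" and "open" are said of these compounds alone.

Compound 1 `Cc1cc(-c2ccccc2)n(/C(N)=N/S(=O)(=O)c2cc(C)c(Cl)cc2SCc2cccc3ccccc23)n1` was examined in an ADME assay on microsomes from liver (Homo sapiens) for metabolic stability, read by LC-MS, using NADPH, tested at 5 uM (a lower number here means that the compound disappears faster, a higher number that the compound lasts longer), where compound 1 gives 0.256 h. For the measured compounds named here, the only other measured compound, compound 2 `Cc1cc(S(=O)(=O)/N=C(\N)n2nccc2-c2ccccc2)c(SCc2cccc(Cl)c2)cc1Cl`, differs from it in more than one place; in this assay compound 2 gives 0.309 h, and the two numbers lie within the scatter of each other, so compound 1 cannot be told apart from its one neighbour. Compound 3 `Cc1cccc(CSc2cc(Cl)c(C)cc2S(=O)(=O)/N=C(\N)n2nc(C)cc2-c2ccccc2)c1` has not yet been measured. It differs from compound 1 in a single place: 3-methylphenyl in place of naphthalen-1-yl on a saturated chain carbon bound to a sulfur. Going by the values given here, no measured pair shows the effect of this kind of change, so there is nothing to go by beyond the two numbers already given. The step from compound 1 to compound 3 is expected to be small, a 1.2-fold higher number from compound 1 to compound 3 (0.07 log units; within the scatter), with no direction beyond the scatter. Compound 3 is estimated to give 0.3 h in this assay, within a range from 0.15 h to 0.6 h.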

Compound 3, half-life: 0.214 h
Estimate against measurement, compound 3: 1.4-fold (0.15 log units) above; low and high end bracket the measured number.
By their numbers in this assay, from the lowest: compounds 3, 1 and 2 (each within the scatter of the next).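

In this assay, exchanging naphthalen-1-yl for 3-methylphenyl gives a 1.2-fold lower number from compound 1 to compound 3 (0.08 log units; within the scatter), so the two compounds cannot be told apart. For the compounds shown here, this is the first pair here that differs in one place only, and it shows that going from 2 six-membered aromatic rings and 10 heavy atoms to one such ring and 7 heavy atoms leaves no readable difference in half-life. Nothing measured here offers an explanation for this result.

A single pair cannot show how far this holds for other groups at this position, such as an amine, a carboxylic acid or a longer chain. It also leaves open whether the same swap would behave alike on a different core.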